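Replacing 5-methylthiophen-2-yl with 4-hydroxyphenyl: expected growth inhibition

A few compounds are considered here, and "the series" means these few. Any claim that something is new, unique, unknown or untested is made for them only; others in the source may bear on it.

In a functional assay on DU-145 cells (Homo sapiens) for inhibition, read by trypan blue exclusion, with a stated time of 96 h (a higher number here means a weaker inhibitor of growth, a lower number a stronger inhibitor of growth), compound 3 (`Cc1ccc(/C=C(/SCc2ccc(Cl)cc2)C(=O)c2ccc(Cl)cc2)s1`) gives 50000 nM, the highest number of the three measured. Compound 1 (`O=C(/C(=C\c1ccc(O)c([N+](=O)[O-])c1)SCc1ccc(Cl)cc1)c1ccc(Cl)cc1`) gives 10000 nM, and compound 2 (`O=C(/C(=C\c1ccc(OCc2ccccc2)cc1)SCc1ccc(Cl)cc1)c1ccc(Cl)cc1`) gives 1000 nM. Compound 4 (`O=C(/C(=C\c1ccc(O)cc1)SCc1ccc(Cl)cc1)c1ccc(Cl)cc1`) differs from compound 3 as follows: 4-hydroxyphenyl in place of 5-methylthiophen-2-yl on a double-bonded chain carbon bound to a double-bonded chain carbon. Going by the values given here, the one measured step that bears on this change is a 5.0-fold higher number from compound 1 to compound 3 (0.70 log units; beyond the scatter), modest but beyond the scatter, with 5-methylthiophen-2-yl in place of 4-hydroxy-3-nitrophenyl. The present change runs the opposite way, though the entering group is 4-hydroxyphenyl. A step of similar size towards a lower number is therefore expected in this assay, estimated as a 6.3-fold lower number from compound 3 to compound 4 (0.80 log units; beyond the scatter). For compound 4 the estimated value is 8000 nM, with an expected range of 2000 nM to 30000 nM.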

Compound 4, concentration for 50% growth inhibition: 10000 nM
Beside the measured number, compound 4's estimate is 1.3-fold (0.10 log units) below it; the measured number falls inside the stated range.
By their numbers in this assay, from the lowest: compound 2; then compounds 1 and 4 (each within the scatter of the next); then compound 3.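

In this assay, going by these compounds alone, 4-hydroxyphenyl in place of 5-methylthiophen-2-yl on the double-bonded chain carbon gives a 5.0-fold lower number from compound 3 to compound 4 (0.70 log units; beyond the scatter), the first direct reading of this swap without the nitro group. Hydrogen in place of nitro gives no change at the digits printed from compound 1 to compound 4 (within the scatter), whereas hydrogen in place of benzyl on the oxygen gives a 10-fold higher number from compound 2 to compound 4 (1.00 log units; beyond the scatter), so at this position the benzyl group matters more in this assay than the nitro group. No evidence is available to explain these steps.

From the compounds shown here alone, it remains open whether a methyl group or a longer chain on that oxygen would match benzyl. An amine in place of the hydroxyl group is also untested in the compounds shown.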